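The source may hold more compounds than are shown below. What is called first, only, known or untested is meant among the compounds shown, and "the series" means these compounds.

Measured in an ADME assay for permeability, using PAMPA, with a stated time of 4 h, at pH 7.4; a higher number here means that the compound crosses the layer faster, a lower number that the compound crosses the layer more slowly
compound 1 `C/C(CN)=C(/F)CN(C[C@H]1Cc2ccccc2CN1)[C@H]1CCCc2cccnc21` gives 220 nm/s
compound 2 `N[C@H]1CC[C@H](CN(C[C@H]2Cc3ccccc3CN2)[C@H]2CCCc3cccnc32)CC1` gives 12 nm/s
compound 3 `N[C@H]1CC[C@H](N(C[C@H]2Cc3ccccc3CN2)[C@H]2CCCc3cccnc32)CC1` gives 37 nm/s

Compound 2 has the lowest number of the three. Compound 4 `C/C(=C/CN)CN(C[C@H]1Cc2ccccc2CN1)[C@H]1CCCc2cccnc21` differs from it as follows: a group of 5 heavy atoms (4 carbon, 1 nitrogen; no ring) in place of a group of 7 heavy atoms (6 carbon, 1 nitrogen; one six-membered non-aromatic ring of carbon only), on a saturated chain carbon bound to an amine nitrogen. Compound 1 also carries an open chain at that place, 2-(aminomethyl)-1-fluoroprop-1-en-1-yl, so the closest guide is an 18-fold lower number from compound 1 to compound 2 (1.26 log units; beyond the scatter), a large step to the 4-aminocyclohexyl group. The modest 3.1-fold higher number from compound 2 to compound 3 (0.49 log units; beyond the scatter) concerns a different place and bears less. Going by the values given here, no measured pair isolates the fluorine of compound 1, so that large step may not carry over in full. A clear rise in this assay is expected, somewhat smaller than that step. The expected step is a 9.2-fold higher number from compound 2 to compound 4 (0.96 log units; beyond the scatter). For compound 4 the estimate is 110 nm/s, with an expected range of 40 nm/s to 280 nm/s.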

Compound 4, apparent permeability: 250 nm/s
Compound 4: middle estimate off by 2.3-fold (0.36 log units), on the low side; the range from low to high includes it.
By their numbers in this assay, from the lowest: compound 2; then compound 3; then compounds 1 and 4 (each within the scatter of the next).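

In this assay the open chain of compound 4 carries no fluorine, yet the step is a 1.1-fold higher number from compound 1 to compound 4 (0.06 log units; within the scatter) so the high number seen with compound 1 does not depend on that atom. The open chain also stands well clear of both ring-bearing compounds, with a 21-fold higher number from compound 2 to compound 4 (1.32 log units; beyond the scatter) and a 6.8-fold higher number from compound 3 to compound 4 (0.83 log units; beyond the scatter) as the two steps.

Nothing measured here explains these steps. On these data alone, whether the double bond matters stays open, and a saturated 4-aminobutyl chain on the same amine nitrogen would test that.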